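The source may report more compounds than this note shows. Statements on the series, on what has been measured and on what is new or still open speak of the compounds shown alone.

Compound 1 `COc1cccc(-c2cc(-c3cc4cc(OC)ccc4[nH]3)no2)c1`: in a functional assay on COLO 320 cells (Homo sapiens) for cytotoxicity, read by WST assay, with a stated time of 72 h (a lower number here means a stronger inhibitor, a higher number a weaker inhibitor), compound 1 gives > 100000 nM, which is a limit of the assay.
Compound 2 `COc1ccc(-c2cc(-c3c(Cl)c4ccccc4n3C)no2)cc1`: in this assay compound 2 gives 78100 nM.
Compound 3 `Cn1c(-c2cc(-c3ccc(C(F)(F)F)cc3)on2)c(Cl)c2ccccc21`: in this assay compound 3 gives > 100000 nM, which is a limit of the assay.

Compound 1 therefore sits at the limit where two of the three values lie (the limit of > 100000 nM in this assay, at which 2 of the 3 values shown sit); only that limit, not a number, is known for it. Compound 4 `COc1cccc(-c2cc(-c3cc4ccccc4[nH]3)no2)c1` differs from compound 1 by hydrogen in place of methoxy on an aromatic carbon. Going by the values given here, the one measured step, an at least 1.2-fold higher number from compound 2 to compound 3 (0.10 log units; that floor lies within the scatter), puts trifluoromethyl in place of methoxy rather than hydrogen, so no measured step bears directly on this change, and that step itself lies within the scatter. Given that compound 1 stands at the limit > 100000 nM, compound 4 is expected to stay weak, with an estimated step of a number no higher from compound 1 to compound 4 (the limit leaves the size open). Compound 4 is estimated at 100000 nM, in the range 40000 nM to 300000 nM.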

Compound 4, half-maximal inhibitory concentration: > 100000 nM
Compound 4 gave a limit, no number; the forecaster's own chance of this, stated with the estimate: 65%; the middle value lies on the limit itself.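

Going by these compounds alone, no step from compound 1 to compound 4 can be read, since each gives only a limit and not a number: the limit of > 100000 nM in this assay, at which 3 of the 4 values shown sit.

On these data alone, whether hydrogen in place of methoxy on an aromatic carbon changes potency in this assay at all therefore stays open.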